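This account rests on a few compounds, and the source may have more. Where it says the series, first, only, none or still open, it means among the compounds named here.

Working notes on the series. Two compounds have been run in an ADME assay on cells for inhibition of cytochrome P450 1A1 (Homo sapiens), read by fluorescence, tested at 10 uM (on this read-out higher numbers stand for more inhibition at the one concentration tested (going by the name of the read-out) and lower numbers for less inhibition), so far. Compound 1 `C#CCOc1cc(-c2nc3ccccc3c(=O)[nH]2)ccc1OC` gives 22.8% in this assay, and compound 2 `O=c1[nH]c(-c2ccc(OS(=O)(=O)c3ccccc3)cc2)nc2ccccc12` gives 19.3%; these two numbers lie within the scatter of each other, so no order can be read between them. Compound 3 `COc1ccc(-c2nc3ccccc3c(=O)[nH]2)cc1OCc1ccc(F)cc1F` is still to be measured. It differs from compound 1 by 2,4-difluorophenyl in place of ethynyl on a saturated chain carbon bound to an oxygen on an aromatic ring. Within the data shown here, no step between measured compounds is available to gauge this change, so the expected step of a number 1.2 percentage points higher from compound 1 to compound 3 (within the scatter) is taken as none beyond the scatter. Compound 3 is therefore estimated at 24%, in the range 8% to 45%.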

Compound 3, a percentage reported as inhibition, at one concentration (the size of the read-out at that concentration, not a potency): 23.8%
Compound 3: the middle estimate sits 0.2 percentage points above what was measured, and the stated range covers the measured number.
By their numbers in this assay, from the lowest: compounds 2, 1 and 3 (each within the scatter of the next).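

Replacing ethynyl with 2,4-difluorophenyl on a saturated chain carbon bound to an oxygen on an aromatic ring gives a number 1 percentage points higher from compound 1 to compound 3 (within the scatter) in this assay. This first step at the position shows that the change from propargyl to 2,4-difluorobenzyl, which adds one six-membered aromatic ring, stays within the scatter. Nothing measured bears on why this is so. Going by these compounds, whether an amine or a carboxylic acid on this chain would give a step beyond the scatter remains open, as does the effect of a longer chain.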